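The compounds below may be only part of what the source reports. "The series", "measured", "known", "first", "only" and "open" are said of these compounds alone.

Measured so far in a functional assay on HT-1080 cells (Homo sapiens) for antiproliferative activity, read by sulforhodamine B assay, with a stated time of 48 h; a lower number here means a stronger inhibitor, a higher number a weaker inhibitor:
Compound 1, `CC(C)c1ccccc1OS(=O)(=O)c1cccc(NC(=O)CCCl)c1`, gives 8200 nM.
Compound 2, `CC(=O)Nc1ccc(S(=O)(=O)Oc2ccccc2C(C)C)cc1`, gives 12000 nM.
Compound 3, `CC(=O)Nc1ccc(S(=O)(=O)Oc2ccccc2I)cc1`, gives 17000 nM.

Compound 2 stands among these three with a number that lies within the usual scatter of both compound 1 and compound 3. For the measured compounds named here, the one step that can be read between measured compounds, a 1.4-fold higher number from compound 2 to compound 3 (0.15 log units; within the scatter), concerns iodo in place of isopropyl on an aromatic carbon. Compound 4, `CC(C)C(=O)Nc1ccc(S(=O)(=O)Oc2ccccc2C(C)C)cc1`, differs from compound 2 by isopropyl in place of methyl on a carbonyl carbon. Going by the values given here, no measured pair shows this change at the carbonyl carbon, and the single step available sits at a different place and is itself within the scatter, so nothing in these numbers points to a shift in this assay beyond the scatter in either direction. For compound 4 the expected value in this assay is 12000 nM, with a range from 5000 nM to 30000 nM. The expected step of no change at the digits printed from compound 2 to compound 4 (within the scatter) is thus one that stays within the scatter.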

Compound 4, half-maximal inhibitory concentration: 4900 nM
Estimate against measurement, compound 4: 2.4-fold (0.39 log units) above; the whole stated range lies above it.
By their numbers in this assay, from the lowest: compounds 4, 1, 2 and 3 (each within the scatter of the next, the first and the last beyond it).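

For the compounds shown here, the carbonyl carbon of the amide proves to be a place where a change can register in this assay: isopropyl in place of methyl gives a 2.4-fold lower number from compound 2 to compound 4 (0.39 log units; beyond the scatter) and so goes beyond the scatter, unlike the one earlier step, which lay within it at a different place. Nothing shown accounts for this step.

As far as these compounds go, whether a longer chain or an amine on this carbonyl carbon would extend, keep or reverse the step remains open. From the compounds shown here alone, it is also open whether isopropyl in place of methyl would give a similar step in the iodo compound 3.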